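From Iodo to Methylamino on a Shared Core

The source may report more compounds than this note shows. Statements on the series, on what has been measured and on what is new or still open speak of the compounds shown alone.

Compound 2 `CCCCCCNC(=O)n1cc(I)c(=O)[nH]c1=O` stands lowest of the two numbers in an assay on HEK293 cells for inhibition of acid ceramidase (Rattus norvegicus), read by LC-MS, with a stated time of 30 min (a higher number here means a weaker inhibitor, a lower number a stronger inhibitor), at 147 nM. Among the measured compounds shown here, compound 1 `CCCCCCNC(=O)n1cc(C)c(=O)[nH]c1=O` gives 1460 nM, and the step of a 9.9-fold lower number from compound 1 to compound 2 (1.00 log units; beyond the scatter) is the only measured step. Compound 3 `CCCCCCNC(=O)n1cc(NC)c(=O)[nH]c1=O` carries the change (methylamino in place of iodo on an aromatic carbon). For the measured compounds named here, no measured step swaps iodo for methylamino; the methyl-to-iodo step only shows that this carbon moves the number strongly. A rise beyond the scatter is therefore expected, a 10-fold higher number from compound 2 to compound 3 (1.01 log units; beyond the scatter). Compound 3 is estimated at 1500 nM, with a range from 400 nM to 6000 nM.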

Compound 3, half-maximal inhibitory concentration: 3400 nM
Beside the measured number, compound 3's estimate is 2.3-fold (0.36 log units) below it, and the stated range covers the measured number.
By their numbers in this assay, from the lowest: compound 2; then compound 1; then compound 3.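

Methylamino in place of iodo gives a 23-fold higher number from compound 2 to compound 3 (1.36 log units; beyond the scatter) in this assay, so the low number of compound 2 does not survive this swap at this aromatic carbon. Methylamino also falls short of methyl, with a 2.3-fold higher number from compound 1 to compound 3 (0.37 log units; beyond the scatter), which means that among these three groups only iodo brings the number down from that of methyl. Nothing shown here explains this order of the groups. Going by these compounds, whether bromo or chloro would hold the low number of iodo remains open, as does whether a plain amine or dimethylamino would behave like methylamino.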